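Swapping the Amino Link for an Ether on the Nitro Ring

The source may report more compounds than this note shows. Statements on the series, on what has been measured and on what is new or still open speak of the compounds shown alone.

Compound 1, `CC1(C)CCC(CN2CCN(c3ccc(C(=O)NS(=O)(=O)c4ccc(NCC5CCOCC5)c([N+](=O)[O-])c4)c(Oc4cnc5[nH]ccc5c4)c3)CC2)=C(c2ccc(C(F)(F)F)c(Cl)c2)C1`: 0.8 nM
Compound 2, `CC(C)C(=O)N1CCC(CNc2ccc(S(=O)(=O)NC(=O)c3ccc(N4CCN(CC5=C(c6ccc(C(F)(F)F)cc6)CC(C)(C)CC5)CC4)cc3Oc3cnc4[nH]ccc4c3)cc2[N+](=O)[O-])CC1`: 2.4 nM
Compound 3, `CC1(C)CCC(CN2CCN(c3ccc(C(=O)NS(=O)(=O)c4ccc(NCC5CCOC5)c([N+](=O)[O-])c4)c(Oc4cnc5[nH]ccc5c4)c3)CC2)=C(c2ccc(C(F)(F)F)cc2)C1`: 4.7 nM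

All three compounds were tested in an assay on isolated protein for displacement of a labelled ligand from Apoptosis regulator Bcl-2 (Homo sapiens), with a stated time of 15 min; a higher number here means a weaker inhibitor, a lower number a stronger inhibitor. Compound 3 shows the highest number of the three; compound 2 lies within the scatter of it, whereas compound 1 sits well beyond it. Compound 4, `CC1(C)CCC(CN2CCN(c3ccc(C(=O)NS(=O)(=O)c4ccc(OCC5CCOC5)c([N+](=O)[O-])c4)c(Oc4cnc5[nH]ccc5c4)c3)CC2)=C(c2ccc(C(F)(F)F)cc2)C1`, has not yet been measured. It differs from compound 3 in one place: (oxolan-3-yl)methoxy in place of ((oxolan-3-yl)methyl)amino on an aromatic carbon. Going by the values given here, the single measured step, a 2.0-fold higher number from compound 2 to compound 3 (0.29 log units; within the scatter), changes the ring carried on the chain and not the atom that joins that chain to the aromatic ring, so it offers no direct guide to this swap. Without a measured precedent, a step of a 2.6-fold higher number from compound 3 to compound 4 (0.41 log units; beyond the scatter) toward a somewhat higher number is expected, with wide uncertainty. Compound 4 is estimated at 12 nM, ranging from 4 nM to 40 nM.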

Compound 4, half-maximal inhibitory concentration: 4.4 nM
The estimate for compound 4 lay 2.7-fold (0.44 log units) above the measured number; low and high end bracket the measured number.
By their numbers in this assay, from the lowest: compound 1; then compounds 2, 4 and 3 (each within the scatter of the next).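

In this assay, (oxolan-3-yl)methoxy in place of ((oxolan-3-yl)methyl)amino gives a 1.1-fold lower number from compound 3 to compound 4 (0.03 log units; within the scatter), so on this aromatic carbon, ortho to a nitro group, the joining atom can change from nitrogen to oxygen with no readable change in the number. The entering group has 0 hydrogen-bond donors against 1 for the leaving group, and the result stays within the scatter. No supporting data are available to explain this result. Going by these compounds, whether a sulfur link or an all-carbon chain would fit here remains open, as does whether the swap holds with another ring on the chain.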